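This account rests on a few compounds, and the source may have more. Where it says the series, first, only, none or still open, it means among the compounds named here.

Working notes on the series. The shared core carries an aryl amine on one side and a small chain on the other; three members have been run in an in vitro ADME assay on microsomes from liver (Mus musculus) for metabolic stability; on this read-out higher numbers stand for fast clearance and lower numbers for slow clearance. Compound 1, `CCc1nc2nc(C)cc(Nc3cccc(Cl)c3)n2n1`, gives 125 mL.min-1.g-1 in this assay. Compound 2, `CCC(F)(F)c1nc2nc(C)cc(Nc3ccc(S(F)(F)(F)(F)F)cc3)n2n1`, gives 6.7 mL.min-1.g-1. Compound 3, `Cc1cc(Nc2ccc(C(F)(F)F)cc2)n2nc(CCO)nc2n1`, gives 6.9 mL.min-1.g-1. Compound 2 thus stands at the lowest of the three numbers, with compound 3 within the scatter of it and compound 1 beyond the scatter, well above it.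

The next step keeps the aryl amine of compound 2 and alters only the chain: 2-methoxyethyl in place of 1,1-difluoropropyl on an aromatic carbon. This gives compound 4, `COCCc1nc2nc(C)cc(Nc3ccc(S(F)(F)(F)(F)F)cc3)n2n1`, not yet measured in this assay. Among the measured compounds shown here, no measured pair shows this exact change, so the expectation rests on compound 2 at 6.7 mL.min-1.g-1 and on compound 3, which carries an oxygen in its chain and sits at 6.9 mL.min-1.g-1. A modest rise beyond the scatter is expected, a 2.4-fold higher number from compound 2 to compound 4 (0.38 log units; beyond the scatter), the chain losing both fluorines. Compound 4 is therefore estimated at 16 mL.min-1.g-1, within 5 mL.min-1.g-1 to 45 mL.min-1.g-1.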

Compound 4, intrinsic clearance in microsomes in the liver assay: 14.1 mL.min-1.g-1
For compound 4 the middle estimate is 1.1-fold (0.05 log units) above the measured one; the range from low to high includes it.
By their numbers in the liver assay, from the lowest: compounds 2 and 3 (each within the scatter of the next); then compound 4; then compound 1.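

Among the compounds shown here, in the liver assay this single change at the chain gives a 2.1-fold higher number from compound 2 to compound 4 (0.32 log units; beyond the scatter), the first reading of this position with the aryl amine held fixed. In a physicochemical assay for lipophilicity, at pH 7.4 (a lower number here means a more polar compound, a higher number a more lipophilic compound), compound 2 gives 3.9 and compound 4 gives 3. Across this one change the two read-outs therefore move in opposite directions: the 2-methoxyethyl compound has the lower distribution coefficient and the higher clearance, so here a lower distribution coefficient did not come with slower clearance.

The change removes both fluorines and brings in the oxygen at once, and the compounds shown do not separate these two parts; a plain propyl chain on the same aromatic carbon would do so. From the compounds shown here alone, how a chain ending in an amine would behave at this position also remains open.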